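A few compounds are considered here, and "the series" means these few. Any claim that something is new, unique, unknown or untested is made for them only; others in the source may bear on it.

Measured compounds:
Compound 1, `CCOC(=O)C(=O)Nc1nc(-c2cc(Br)no2)cs1`, in a functional assay on the whole organism with Rattus norvegicus as the target; a lower number here means that less compound is needed, a higher number that more compound is needed for the effect: 12 mg/kg
Compound 2, `CCOCCOC(=O)C(=O)Nc1nc(-c2cc(C)no2)cs1`, in this assay: 0.04 mg/kg

Compound 2 stands at the lowest number of the two measured compounds; the nearest number, that of compound 1, is higher and lies beyond the scatter. Among the compounds with values here, the two measured compounds differ in more than one place, so no single step between them is known. Compound 3, `CCOC(=O)C(=O)Nc1nc(-c2cc(C)no2)cs1`, is not yet measured. It differs from compound 2 in one place: hydrogen in place of ethoxy on a saturated chain carbon, two bonds along the chain from an oxygen next to a carbonyl group. Within the data shown here, no measured pair shows this change on its own, so the size of the step can only be guessed from how far the side chain on the ester sits from the shared core. A moderate rise in the number, near the edge of the scatter, is expected, giving a step from compound 2 to compound 3 of a 3.8-fold higher number from compound 2 to compound 3 (0.57 log units; beyond the scatter). Compound 3 is therefore estimated at 0.15 mg/kg, with a range from 0.02 mg/kg to 1.5 mg/kg.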

Compound 3, dose for half-maximal effect: 0.2 mg/kg
Compound 3: middle estimate off by 1.3-fold (0.12 log units), on the low side; the measured number falls inside the stated range.
By their numbers in this assay, from the lowest: compound 2; then compound 3; then compound 1.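

Cutting 2-ethoxyethoxy back to ethoxy brings a 5.0-fold higher number from compound 2 to compound 3 (0.70 log units; beyond the scatter) in this assay and shows, in a single change, that the ethoxy on the saturated chain carbon contributes a modest but real part of the low number of compound 2. Methyl in place of bromo on an aromatic carbon brings a 60-fold lower number from compound 1 to compound 3 (1.78 log units; beyond the scatter) and is the larger of the two steps, so most of the wide gap between the first two compounds goes with this aromatic position rather than with the chain. No measurement at hand gives a reason for either step.

The compounds shown leave open whether a longer chain or a 2-hydroxyethoxy group would hold the number as low as 2-ethoxyethoxy does. They also leave open whether chloro or trifluoromethyl on the aromatic carbon would behave like methyl or like bromo.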